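A few compounds are considered here, and "the series" means these few. Any claim that something is new, unique, unknown or untested is made for them only; others in the source may bear on it.

Series notes. Compound 1 `Cc1noc(-c2c(F)cccc2-c2ccc([C@@H](C)Nc3nccc(Cl)c3NC(=O)CC#N)cc2)n1` carries a 3-methyl-1,2,4-oxadiazol-5-yl on an aromatic carbon of a six-membered aromatic ring of carbon only, ortho to a fluoro group and ortho to a large group. In an in vivo ADME assay on the whole organism for pharmacokinetics, with Canis familiaris (Canis lupus familiaris) as the target, at a dose of 3 mg/kg by the oral route (on this read-out lower numbers stand for lower oral bioavailability and higher numbers for higher oral bioavailability), compound 1 gives 14%. For the measured compounds named here, compound 2 `COC(=O)c1c(Cl)cccc1-c1ccc([C@@H](C)Nc2nccc(Cl)c2NC(=O)CC#N)cc1` is the only other compound with a number here, and in this assay compound 2 gives 23%. Going by the values given here, the two readings sit within the scatter of each other, so compound 1 stands at the lower of two numbers without that gap carrying any meaning, and no step between the two is set out.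

Compound 3 `C[C@@H](Nc1nccc(Cl)c1NC(=O)CC#N)c1ccc(-c2cccc(F)c2-c2nnn(C)n2)cc1` differs from compound 1 in one place: 2-methyl-2H-tetrazol-5-yl in place of 3-methyl-1,2,4-oxadiazol-5-yl on an aromatic carbon. The shared core and everything else stay as in compound 1. Among the compounds with values here, no measured pair in this set shows what such an exchange does in this assay, so the expectation rests on the two readings alone and on the small size of the change. No step beyond the scatter is expected, and the step is estimated at a number 4 percentage points higher from compound 1 to compound 3 (within the scatter). Compound 3 is expected to give 18%, in a range from 6% to 35%.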

Compound 3, oral bioavailability: 69%
The estimate for compound 3 lay 51 percentage points below the measured number, and the stated range ends below it.
By their numbers in this assay, from the lowest: compounds 1 and 2 (each within the scatter of the next); then compound 3.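

In this assay, exchanging the 3-methyl-1,2,4-oxadiazol-5-yl for a 2-methyl-2H-tetrazol-5-yl, ortho to a fluoro group and ortho to a large group, gives a number 55 percentage points higher from compound 1 to compound 3 (beyond the scatter). This shows that the reading at this position depends strongly on which five-membered aromatic ring is attached, even though both groups have 6 heavy atoms, no hydrogen-bond donors and no net charge; they differ in ring atoms, with 2 carbon and 4 nitrogen against 3 carbon, 2 nitrogen and 1 oxygen, and in having 4 rather than 3 hydrogen-bond acceptors. Nothing available here bears on what lies behind the size of this step.

Going by these compounds, the step rests on a single pair, so it remains open whether it would carry over with a chloro group in place of the fluoro group on the same ring. Also open, on these data alone, is how the reading would respond at this position to 1-methyl-1H-tetrazol-5-yl, a primary amide or a carboxylic acid in place of 2-methyl-2H-tetrazol-5-yl.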